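Working notes: from compound 2 to compound 3

The compounds below may be only part of what the source reports. "The series", "measured", "known", "first", "only" and "open" are said of these compounds alone.

Measured so far in a functional assay on HepG2 cells (Homo sapiens) for antiproliferative activity, read by MTT assay, with a stated time of 48 h (a higher number here means a weaker inhibitor, a lower number a stronger inhibitor), as follows:
Compound 1 `COc1ccc(-c2c(Nc3cccc(C(F)(F)F)c3)c3ccc(OC)cc3oc2=O)cc1` gives 57300 nM
Compound 2 `COc1ccc(-c2c(Nc3ccc(C)cc3)c3ccc(O)cc3oc2=O)cc1` gives 88300 nM

These two values lie within the usual scatter of each other, so compound 2 holds no separate rank against compound 1, and the pair marks a single level for the series.

Compound 3 `COc1ccc(-c2c(Nc3cccc(C(F)(F)F)c3)c3ccc(O)cc3oc2=O)cc1` has not been measured. It differs from compound 2 on a nitrogen on an aromatic ring, with 3-(trifluoromethyl)phenyl in place of 4-methylphenyl (3-(trifluoromethyl)phenyl in place of 4-methylphenyl on a nitrogen on an aromatic ring).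

Going by the values given here, no measured step isolates this change, so the data give no direct size for it. The entering group also stands on compound 1 (57300 nM), and that value sits within the scatter of compound 2 (88300 nM). On that basis, no step beyond the scatter is expected in this assay.

The expected change is small (a 1.5-fold lower number from compound 2 to compound 3 (0.17 log units; within the scatter)), and its direction remains uncertain.

Compound 3 is estimated at 60000 nM (expected range 25000 nM to 120000 nM).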

Compound 3, half-maximal inhibitory concentration: 53600 nM
Compound 3: middle estimate off by 1.1-fold (0.05 log units), on the high side; measured number inside the range.
By their numbers in this assay, from the lowest: compounds 3, 1 and 2 (each within the scatter of the next).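

In this assay, the nitrogen on an aromatic ring now has its first measured step: 3-(trifluoromethyl)phenyl in place of 4-methylphenyl (a 1.6-fold lower number from compound 2 to compound 3 (0.22 log units; within the scatter)) stays within the scatter, so this exchange of one aryl group for the other does not separate the two compounds at this level of activity. Compound 3 also links compound 1 and compound 2, which differ in two places, and gives the oxygen on an aromatic ring its first measured step: hydrogen in place of methyl (a 1.1-fold lower number from compound 1 to compound 3 (0.03 log units; within the scatter)) likewise stays within the scatter, so neither single change shown here moves the series off its one level. No measurement that could explain either step accompanies these values.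

Still open, on these data alone, is whether a carboxylic acid or an amine carried on the aryl group at the nitrogen, or a longer chain in place of methyl on the oxygen, would give a step beyond the scatter. With only 3-(trifluoromethyl)phenyl and 4-methylphenyl shown on the nitrogen, and only hydrogen and methyl on the oxygen, the compounds shown do not say how far this flat picture extends.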